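The source may hold more compounds than are shown below. What is called first, only, known or untested is meant among the compounds shown, and "the series" means these compounds.

Measured compounds:
Compound 1 `COCC1=CS(=O)(=O)c2ccccc2C1=O`, which in a functional assay on the whole organism for inhibition, with Mus musculus as the target, at a dose of 10 mg/kg (a higher number here means more inhibition at the dose given (going by the name of the read-out), a lower number less inhibition), gives 99.9%.
Compound 2 `O=C1C(COCCBr)=CS(=O)(=O)c2ccccc21`, which in this assay gives 100%.
Compound 3 `O=C1C(CI)=CS(=O)(=O)c2ccccc21`, which in this assay gives 98%.

All three numbers sit close together near the top of the scale. Compound 1 stands second highest of the three; the nearest of the other two lies a number 0.1 percentage points higher from compound 1 to compound 2 (within the scatter), the furthest lies a number 1.9 percentage points lower from compound 1 to compound 3 (within the scatter), and between those two the step is a number 2 percentage points lower from compound 2 to compound 3 (within the scatter), so every measured step is within the scatter.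

Compound 4 `CCNC(=O)OCC1=CS(=O)(=O)c2ccccc2C1=O` differs from compound 1 in one place: ethylcarbamoyl in place of methyl on an oxygen on a saturated carbon. Within the data shown here, the one measured step that touches the same oxygen, the bromomethyl added from compound 1 to compound 2, changed nothing beyond the scatter, and the two steps that swapped the whole group on the chain carbon did the same. Among the measured compounds shown here, no measured step tests an ethylcarbamoyl, so the expectation rests on the flatness of these three steps. Compound 4 is therefore expected to give about 97% in this assay, between 85% and 100%, which means an expected step of a number 2.9 percentage points lower from compound 1 to compound 4 (within the scatter), within the scatter.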

Compound 4, a percentage reported as inhibition, in the whole organism at one dose (the size of the read-out at that dose, not a potency): 99.3%
The estimate for compound 4 lay 2.3 percentage points below the measured number, within the range that was stated.
By their numbers in this assay, from the lowest: compounds 3, 4, 1 and 2 (each within the scatter of the next).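

In this assay, the ethylcarbamoyl group brings onto this oxygen a double bond and a hydrogen-bond donor that none of the earlier groups on the chain has, yet the result is a number 0.6 percentage points lower from compound 1 to compound 4 (within the scatter). The comparisons with the other two compounds agree: the result is a number 1.3 percentage points higher from compound 3 to compound 4 (within the scatter) and a number 0.7 percentage points lower from compound 2 to compound 4 (within the scatter), so at this position the four groups, including this larger one, are not told apart by this read-out. No evidence is available on why this is so.

With all the numbers close together near the top of the scale, the compounds shown do not reveal which change at this position would lower the inhibition. On these data alone, whether an amine, a carboxylic acid or a free hydroxyl on the saturated chain carbon would keep the number there remains open, as does the effect of any change on the shared core.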